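From phenyl to (dimethylamino)methyl: compound 2 and compound 4

The source may hold more compounds than are shown below. What is called first, only, known or untested is meant among the compounds shown, and "the series" means these compounds.

The series is read in an ADME assay on HepG2 cells (Homo sapiens) for cytotoxicity, read by MTT assay, with a stated time of 24 h; a higher number here means that more compound is tolerated, a lower number that less compound is tolerated. Compound 1 (`CN(C)c1ccc(-c2cn(-c3ccnc4cc(Cl)ccc34)nn2)cc1`) reports > 2860000 nM, which is a limit of the assay and not a number. Compound 3 (`COc1ccc2cc(-c3cn(-c4ccnc5cc(Cl)ccc45)nn3)ccc2c1`) reports > 2590000 nM, which is also a limit. Going by the values given here, compound 2 (`Clc1ccc2c(-n3cc(-c4ccccc4)nn3)ccnc2c1`) gives 574000 nM, the only actual number in the set. Its standing against the other two rests on limits alone.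

Compound 4 (`CN(C)Cc1cn(-c2ccnc3cc(Cl)ccc23)nn1`) is not yet measured. Relative to compound 2 it carries this change: (dimethylamino)methyl in place of phenyl on an aromatic carbon.

Among the compounds with values here, one measured step bears on this change: an at least 4.9-fold lower number from compound 1 to compound 2 (0.69 log units; beyond the scatter), with hydrogen in place of dimethylamino on an aromatic carbon. That step lies beyond the scatter, and the compound carrying dimethylamino sits on the higher side. Within the data shown here, it is an indirect guide, however, as the whole phenyl leaves in compound 4 and no measured step shows that loss. A modest move to a higher number in this assay is therefore expected, with wide uncertainty.

The estimated step is a 2.1-fold higher number from compound 2 to compound 4 (0.32 log units; beyond the scatter). For compound 4 the expected value is 1200000 nM, with an estimated range of 400000 nM to 3000000 nM.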

Compound 4, half-maximal cytotoxic concentration: 1850000 nM
Beside the measured number, compound 4's estimate is 1.5-fold (0.19 log units) below it; the measured number falls inside the stated range.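

In this assay, going by these compounds alone, a 3.2-fold higher number from compound 2 to compound 4 (0.51 log units; beyond the scatter) is a direct reading of what the earlier compounds could only hint at: the whole phenyl can leave this aromatic carbon of the five-membered aromatic ring with 3 nitrogen, and the number moves up beyond the scatter. The earlier step changed only a group carried on the phenyl, and it rested on a limit, whereas this step joins two actual numbers, so its size is known and not merely bounded. The series therefore does not need an aromatic ring at this place to reach a higher number in this assay, although nothing measured here accounts for the step.

The single change swaps out a ring and brings in an amine nitrogen together, so the compounds shown leave open which of the two goes with the higher number. A plain methyl or a cyclohexyl at this carbon would separate the two, and a longer chain ending in the same dimethylamino would show whether the distance of that nitrogen from the ring matters.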